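One Stereocentre Inverted in a Potent Pair

A few compounds are considered here, and "the series" means these few. Any claim that something is new, unique, unknown or untested is made for them only; others in the source may bear on it.

Measured so far in a functional assay on the whole organism (strain Hartley) for inhibition, with Cavia porcellus as the target, with stated times of 2 min and 15 min; on this read-out lower numbers stand for an effect already at smaller amounts and higher numbers for an effect only at larger amounts of compound:
- compound 1 `CCCCC[C@@H](O)/C=C/C1CCC(=O)[C@@H]1CCCCSCC(=O)O`: 0.0113 mg/kg
- compound 2 `CCCCC(C)(C)[C@H](O)/C=C/C1CCC(=O)[C@@H]1CCCCSCC(=O)O`: 0.0242 mg/kg

Both compounds act at very small doses. Compound 2, at 0.0242 mg/kg, has the higher of the two numbers, and its gap to compound 1 lies just beyond the usual scatter. Compound 3 `CCCCC(C)(C)[C@@H](O)/C=C/C1CCC(=O)[C@@H]1CCCCSCC(=O)O` is the next to consider. the two compounds have the same atoms and bonds; at least one stereo element is drawn with a configuration in one of them and without one in the other: 1 of 4 stereo elements differ; a stereocentre at a saturated chain carbon is drawn R in compound 2 and S in compound 3 It has the same atoms and bonds as compound 2, and only a stereocentre at a saturated chain carbon changes, drawn R in compound 2 and S in compound 3. Among the measured compounds shown here, no measured step shows what such an inversion does here, so the forecast is uncertain. A mirror-image change at one centre can matter greatly, so a loss is more likely than a gain, and a higher number is expected in this assay. The expected shift is a 3.3-fold higher number from compound 2 to compound 3 (0.52 log units; beyond the scatter). For compound 3 the estimated value is 0.08 mg/kg, with an expected range of 0.015 mg/kg to 0.5 mg/kg.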

Compound 3, dose for half-maximal effect: 0.324 mg/kg
For compound 3 the middle estimate is 4.1-fold (0.61 log units) below the measured one, and the stated range covers the measured number.
By their numbers in this assay, from the lowest: compound 1; then compound 2; then compound 3.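

Inverting the stereocentre at a saturated chain carbon, with every atom and bond left unchanged, gives a 13-fold higher number from compound 2 to compound 3 (1.13 log units; beyond the scatter) in this assay, so the drawn configuration at this one centre matters strongly. With this configuration, 1,1-dimethylpentyl in place of pentyl goes with a 29-fold higher number from compound 1 to compound 3 (1.46 log units; beyond the scatter), whereas compound 2, carrying the same group, gives 0.0242 mg/kg, so the effect of that group cannot be judged apart from the configuration. One caution applies to reading the inversion as a comparison of two known configurations: the fact that one of compounds 2 and 3 is drawn with a defined configuration and the other without, at the place where they differ

From the compounds shown here alone, it remains open whether the same inversion would cost as much with pentyl in place of 1,1-dimethylpentyl. Also open, going by these compounds, is how a single methyl group or a longer chain in place of 1,1-dimethylpentyl would behave in this assay.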